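A few compounds are considered here, and "the series" means these few. Any claim that something is new, unique, unknown or untested is made for them only; others in the source may bear on it.

Measured compounds:
- compound 1: `COc1cc(O)c([C@@H](/C=C/c2ccc(O)cc2)CCCCc2ccc(O)cc2)c(O)c1C(=O)/C=C/c1ccc(O)cc1` — 26.5 uM
- compound 2: `COc1cc(O)c([C@@H]2C[C@H](CCc3ccc(O)cc3)O[C@@H](c3ccc(O)cc3)C2)c(O)c1C(=O)/C=C/c1ccc(O)cc1` — 1.71 uM

Both were tested in a functional assay on HT-1080 cells (Homo sapiens) for cytotoxicity, read by MTT assay; a higher number here means that more compound is needed for the effect, a lower number that less compound is needed. Compound 2 has the lowest number of the two; its nearest neighbour, compound 1, needs a considerably larger concentration for the same effect, and that gap lies well beyond the usual scatter of this kind of measurement. Among the measured compounds shown here, no step between compounds that differ in only one place has been worked out here, so what the two values show is all that can be said of them.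

The next compound, compound 3, is `COc1cc(O)c([C@@H]2C[C@H](CCc3ccc(O)cc3)O[C@H](c3ccc(O)cc3)C2)c(O)c1C(=O)/C=C/c1ccc(O)cc1`. Compared with compound 2, the change is this: the two compounds have the same atoms and bonds and differ only in configuration as drawn: 1 of 4 stereo elements differ; a stereocentre at a saturated ring carbon is drawn R in compound 2 and S in compound 3. Nothing leaves and nothing enters; only the drawn configuration at one saturated ring carbon is turned around.

For the measured compounds named here, there is no measured step of this kind among the compounds above to lean on. A change of configuration alone can leave this assay unmoved or shift it either way; the expectation here is a small loss, close to or just beyond the scatter, so that compound 3 is estimated at 3.5 uM, within a range from 1.2 uM to 12 uM, an expected step of a 2.0-fold higher number from compound 2 to compound 3 (0.31 log units; beyond the scatter).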

Compound 3, concentration for half-maximal effect: 10.4 uM
Beside the measured number, compound 3's estimate is 3.0-fold (0.47 log units) below it, and the stated range covers the measured number.
By their numbers in this assay, from the lowest: compound 2; then compound 3; then compound 1.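

In this assay, among the compounds shown here, the turn from R to S at this saturated ring carbon brings a 6.1-fold higher number from compound 2 to compound 3 (0.78 log units; beyond the scatter) and so gives the first measured step at this position. The step is modest but lies beyond the usual scatter, which shows that the drawn configuration at this one carbon matters in this cell read-out even though no atom leaves or enters. The shift can be assigned to this single stereocentre alone, because nothing else separates the two structures: the fact that compounds 2 and 3 differ only in the configuration as drawn.

One pair gives the size and direction of the change at one carbon only, so the compounds shown leave open how the other three stereo elements would behave and why this one changes the read-out. They also leave open whether the same gap between R and S would hold in compounds carrying an amine or a carboxylic acid on the shared core.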